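Solubility notes: carboxy in place of methyl on compound 1

The source may hold more compounds than are shown below. What is called first, only, known or untested is meant among the compounds shown, and "the series" means these compounds.

Measured so far in a physicochemical assay for solubility, read by LC-MS, in phosphate buffer, measured as thermodynamic solubility, with a stated time of 24 h, at pH 7.4; on this read-out lower numbers stand for lower solubility and higher numbers for higher solubility:
compound 1 `Cc1ccc(-c2c[nH]c3ncc(-c4cnn(C)c4)cc23)cc1` — 7000 nM
compound 2 `Cn1cc(-c2cnc3[nH]cc(-c4cccc(F)c4)c3c2)cn1` — 3000 nM
compound 3 `Cn1cc(-c2cnc3[nH]cc(-c4ccccc4F)c3c2)cn1` — 14000 nM

Compound 1 sits between the other two numbers. Its gap to compound 3 is within the scatter (a 2.0-fold higher number from compound 1 to compound 3 (0.30 log units; within the scatter)), so no order between those two can be read. Among the compounds with values here, compound 2 lies lower, by a 2.3-fold lower number from compound 1 to compound 2 (0.37 log units; beyond the scatter), and the step of a 4.7-fold higher number from compound 2 to compound 3 (0.67 log units; beyond the scatter) is the widest spread in this assay so far; both are modest.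

Compound 4 `Cn1cc(-c2cnc3[nH]cc(-c4ccc(C(=O)O)cc4)c3c2)cn1` differs from compound 1 by carboxy in place of methyl on an aromatic carbon. The three measured steps all exchange one substituent on the phenyl ring for another and stay modest in size. None of them brings in a carboxy group or changes the donor and acceptor count, so they set only the scale of what a phenyl substitution has done here, not the direction for this particular exchange.

Within the data shown here, the step of a 7.1-fold higher number from compound 1 to compound 4 (0.85 log units; beyond the scatter) is therefore an expectation resting on no directly comparable pair, and the range is kept wide. In this assay compound 4 is expected to give 50000 nM, within a range from 10000 nM to 250000 nM.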

Compound 4, solubility: 850000 nM
For compound 4 the middle estimate is 17-fold (1.23 log units) below the measured one; measured number above the stated range.
By their numbers in this assay, from the lowest: compound 2; then compounds 1 and 3 (each within the scatter of the next); then compound 4.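

In this assay, within the data shown here, carboxy in place of methyl on an aromatic carbon, para to a large group, gives a 120-fold higher number from compound 1 to compound 4 (2.08 log units; beyond the scatter), a large step that clearly exceeds the widest step among the earlier compounds, a 4.7-fold higher number from compound 2 to compound 3 (0.67 log units; beyond the scatter). Among these compounds, the earlier exchanges at this phenyl ring, all among methyl and fluorine substituents, showed only modest movement, so this result is the first sign that a change at this ring can shift the read-out on a much larger scale. The exchange adds two oxygen atoms, one hydrogen-bond donor and one hydrogen-bond acceptor, but no measurement shown here links the step to any one of these features or to any property of the compounds.

Among the compounds shown here, since compound 4 is the only compound with a carboxy group, this single step supports no general pattern, and it remains open whether a methyl ester, a primary amide or an amine on the same aromatic carbon would give a step of similar size. Also open, going by these compounds, is how a carboxylic acid at the end of a longer chain, or carboxy at another carbon of the same ring, would read in this assay.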